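The source may hold more compounds than are shown below. What is called first, only, known or untested is meant among the compounds shown, and "the series" means these compounds.

Measured in an ADME assay on microsomes from liver (Rattus norvegicus) for metabolic stability, read by LC-MS, using NADPH, at 37 degrees C; a lower number here means that the compound disappears faster, a higher number that the compound lasts longer:
- compound 1 `Cc1ccc(C)c(-c2nc(CN3CCC(C(=O)NCCCN4C[C@H](C)C[C@H](C)C4)CC3)c(C)o2)c1`: 0.5 h
- compound 2 `Cc1cc(C)c(-c2nc(CN3CCC(C(=O)NCCCN4C[C@H](C)C[C@H](C)C4)CC3)c(C)o2)c(C)c1`: > 0.5 h, a limit and not a number
- compound 3 `Cc1ccccc1-c1nc(CN2CCC(C(=O)NCCCN3CC(C)(C)CC(C)(C)C3)CC2)c(C)o1`: 0.095 h

Only two of these results are actual numbers. Compound 1 at 0.5 h has the higher one, and compound 3 at 0.095 h lies lower, by more than the usual scatter of repeated measurements. Compound 3 differs from compound 1 in more than one place, so this gap cannot be assigned to any single change.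

The compound still to be measured is compound 4 `Cc1oc(-c2ccccc2Cl)nc1CN1CCC(C(=O)NCCCN2C[C@H](C)C[C@H](C)C2)CC1`. It keeps the rest of compound 1 and changes one group: 2-chlorophenyl in place of 2,5-dimethylphenyl on an aromatic carbon. The new 2-chlorophenyl sits on an aromatic carbon of a five-membered aromatic ring with 1 nitrogen and 1 oxygen.

Within the data shown here, only one measured step changes the group at this place: a number no lower from compound 1 to compound 2 (the limit leaves the size open). That step ends at a limit, so it gives a direction but no size, and it involves a different new group. With so little to go on, the expectation in this assay stays close to the starting value, with no clear direction. The expected change is a 1.3-fold lower number from compound 1 to compound 4 (0.10 log units; within the scatter), which stays within the scatter. For compound 4 the estimated half-life is 0.4 h, with an expected range from 0.15 h to 0.8 h.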

Compound 4, half-life: 0.25 h
Compound 4: the middle estimate sits 1.6-fold (0.20 log units) above what was measured; low and high end bracket the measured number.
By their numbers in this assay, from the lowest: compound 3; then compounds 4 and 1 (each within the scatter of the next).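

In this assay, among these compounds, this is the first step at this position whose size can be read: a 2.0-fold lower number from compound 1 to compound 4 (0.30 log units; within the scatter). Replacing 2,5-dimethylphenyl with 2-chlorophenyl, a ring with a single chlorine in place of two methyl groups, therefore does not shift the half-life beyond the scatter, while the rest of the molecule stays the same. The comparison with the trimethylated ring gives only a floor, an at least 2.0-fold lower number from compound 2 to compound 4 (0.30 log units; that floor lies within the scatter), and compound 2 stands at a limit and not at a number: the limit of > 0.5 h in this assay, at which 1 of the 4 values shown sits.

The compounds shown do not tell whether the chlorine itself or the loss of the methyl groups matters more, since both happen in the same step, and a 2-methylphenyl group on the core of compound 1 would be needed to separate the two. From the compounds shown here alone, how the half-life responds to other groups at this place, such as an unsubstituted phenyl, a 2-fluorophenyl or a 2-methoxyphenyl, also stays open, and so does whether any group here can move it beyond the scatter.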